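A few compounds are considered here, and "the series" means these few. Any claim that something is new, unique, unknown or untested is made for them only; others in the source may bear on it.

Working notes on the series. Compound 1 `CSc1ccc(C)cc1NCC1=NCCN1` and compound 2 `CSc1ccc(Cl)cc1NCC1=NCCN1` share one core and differ at a single aromatic carbon, where a chloro replaces a methyl. In an assay for binding affinity to Alpha-1B adrenergic receptor (Homo sapiens), read by radioligand binding (a higher number here means a weaker inhibitor, a lower number a stronger inhibitor), compound 1 gives 123 nM and compound 2 gives 69.2 nM; the step of a 1.8-fold lower number from compound 1 to compound 2 (0.25 log units; within the scatter) lies within the scatter, so compound 2 stands at the lower of the two numbers without being separated from compound 1 in any reliable way.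

Compound 3 `CSc1ccc(C(F)(F)F)cc1NCC1=NCCN1` follows from compound 2 by the change (trifluoromethyl in place of chloro on an aromatic carbon). For the measured compounds named here, no measured step swaps chloro for trifluoromethyl anywhere. Going by the values given here, the only step recorded is a 1.8-fold lower number from compound 1 to compound 2 (0.25 log units; within the scatter), and it bears on the same position; as it stayed within the scatter, no move beyond the scatter is expected in this assay for compound 3 in either direction, with the step of a 1.3-fold higher number from compound 2 to compound 3 (0.11 log units; within the scatter) taken as the working expectation. Compound 3 is therefore estimated at 90 nM in this assay, with a range of 35 nM to 230 nM.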

Compound 3, inhibition constant: 2040 nM
Compound 3: middle estimate off by 23-fold (1.36 log units), on the low side, and the stated range ends below it.
By their numbers in this assay, from the lowest: compounds 2 and 1 (each within the scatter of the next); then compound 3.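

The position para to a methylsulfanyl group is not indifferent to its substituent in this assay: the swap of chloro for trifluoromethyl gives a 29-fold higher number from compound 2 to compound 3 (1.47 log units; beyond the scatter), and the swap of methyl for trifluoromethyl gives a 17-fold higher number from compound 1 to compound 3 (1.22 log units; beyond the scatter). The tolerance suggested by methyl and chloro, which stayed within the scatter of each other, therefore does not extend to trifluoromethyl, and the earlier step gave no sign of this limit. Nothing available explains why trifluoromethyl parts from the other two groups.

Three groups at one carbon on one shared core do not establish a trend across substituents at this position. Going by these compounds, whether the higher number is peculiar to trifluoromethyl remains open, as does where groups such as methoxy, nitrile or ethyl would fall at this carbon.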